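Adding chloro to a weakly cytotoxic anilide

This account rests on a few compounds, and the source may have more. Where it says the series, first, only, none or still open, it means among the compounds named here.

Measured in a functional assay on HL-60 cells (Homo sapiens) for cytotoxicity, read by luminescence and CellTiter-Glo, with a stated time of 3 days; on this read-out higher numbers stand for weaker inhibition and lower numbers for stronger inhibition:
Compound 1 `O=C(Nc1cc(C(F)(F)F)cc(C(F)(F)F)c1)c1cc(Br)c(-c2ccccc2)cc1O`: 430 nM
Compound 2 `O=C(Nc1cc(C(F)(F)F)cc(C(F)(F)F)c1)c1ccc(-c2ccccc2)cc1O`: 1140 nM

Of these two, compound 2 has the higher number, 1140 nM, which makes it the weaker inhibitor of the pair. The next structure, compound 3 `O=C(Nc1cc(C(F)(F)F)cc(C(F)(F)F)c1)c1cc(Cl)c(-c2ccccc2)cc1O`, keeps the core of compound 2 and makes one change: chloro in place of hydrogen on an aromatic carbon. In words, this is chloro in place of hydrogen on an aromatic carbon, ortho to a phenyl group and para to a hydroxy group.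

Going by the values given here, one measured step bears on this change: a 2.7-fold higher number from compound 1 to compound 2 (0.42 log units; beyond the scatter). There, hydrogen replaces bromo on that same carbon, and the step is modest but beyond the scatter. Read in reverse, it points toward a lower number when a halogen enters. Among the compounds with values here, no chloro compound has been measured yet, so this single bromo comparison is the only guide. A modest step toward a lower number is therefore expected in this assay, similar to or slightly smaller than the bromo step. The expected step is a 2.2-fold lower number from compound 2 to compound 3 (0.34 log units; beyond the scatter). Compound 3 is estimated at 520 nM, with an expected range of 260 nM to 1000 nM.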

Compound 3, half-maximal inhibitory concentration: 790 nM
Compound 3: the middle estimate sits 1.5-fold (0.18 log units) below what was measured, within the range that was stated.
By their numbers in this assay, from the lowest: compounds 1, 3 and 2 (each within the scatter of the next, the first and the last beyond it).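

In this assay, chloro in place of hydrogen on the aromatic carbon ortho to a phenyl group and para to a hydroxy group gives a 1.4-fold lower number from compound 2 to compound 3 (0.16 log units; within the scatter), so this change, unlike the exchange of bromo and hydrogen on the same carbon, stays inside the usual scatter. Chloro in place of bromo there gives a 1.8-fold higher number from compound 1 to compound 3 (0.26 log units; within the scatter), which also stays inside the scatter, so compound 3 cannot be separated from either neighbour, although compound 1 and compound 2 are separated from each other. A difference beyond the scatter at this position therefore rests on bromo alone among the groups shown, and nothing given here offers an explanation for it.

The compounds shown leave open how other groups on this carbon, such as fluoro, iodo, methyl or methoxy, would read in this assay. They also leave open whether the bromo result would hold with an amine or a carboxylic acid on the phenyl group.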